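Working notes: bromo to fluorophenyl on a two-compound series

A few compounds are considered here, and "the series" means these few. Any claim that something is new, unique, unknown or untested is made for them only; others in the source may bear on it.

Measured so far:
compound 1, `CC(C)=CCOc1c(C)c(C)c2c(c1C)CCC(C)(COc1ccc(/C=C3\SC(=O)NC3=O)cc1Br)O2`, 53%
compound 2, `C=CCOc1c(C)c(C)c2c(c1C)CCC(C)(COc1ccc(/C=C3\SC(=O)NC3=O)cc1Br)O2`, 105%

In a functional assay on MCF7 cells (Homo sapiens), tested at 7.5 uM (a lower number here means a stronger effect, a higher number a weaker effect of the compound at the concentration tested), compound 1 gives 53%, the lowest of the two numbers in hand, and compound 2 gives 105%. Within the data shown here, the one measured step, a number 52 percentage points higher from compound 1 to compound 2 (beyond the scatter), puts vinyl in place of 2-methylprop-1-en-1-yl on a saturated chain carbon bound to an oxygen on an aromatic ring, so the 2-methylprop-1-en-1-yl chain of compound 1 goes with the stronger effect.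

The open compound is compound 3, `CC(C)=CCOc1c(C)c(C)c2c(c1C)CCC(C)(COc1ccc(/C=C3\SC(=O)NC3=O)cc1-c1ccc(F)cc1)O2`. It differs from compound 1 by 4-fluorophenyl in place of bromo on an aromatic carbon. Among the measured compounds shown here, this change sits on the other aromatic ring, far from the chain that the measured step varied, and no measured step touches the bromo position; nothing in the two numbers speaks directly to it. The expectation therefore rests on compound 1 alone, with 53% as anchor and a broad range on either side. The step of a number 2 percentage points higher from compound 1 to compound 3 (within the scatter) is expected to stay near zero, with the scatter and the lack of any related step allowed for. Compound 3 is estimated at 55%, between 30% and 85%.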

Compound 3, a percentage reported as activity, at one concentration (the size of the read-out at that concentration, not a potency): 85%
Compound 3: the middle estimate sits 30 percentage points below what was measured; low and high end bracket the measured number.
By their numbers in this assay, from the lowest: compound 1; then compound 3; then compound 2.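

In this assay, the bromo position proves responsive: 4-fluorophenyl in place of bromo on an aromatic carbon gives a number 32 percentage points higher from compound 1 to compound 3 (beyond the scatter). The read-out of this series at the concentration tested therefore depends on this aromatic substituent as well as on the chain varied earlier, and replacing a single bromine with a group of seven heavy atoms carrying a six-membered aromatic ring goes with a weaker effect, with neither group adding hydrogen-bond donors, acceptors or net charge. No available data explain why the effect weakens at this position.

The compounds shown leave open whether the weaker effect belongs to the aryl group as a whole or to its fluorine, and whether a chloro, a methyl, an unsubstituted phenyl or a phenyl carrying an amine would stay closer to compound 1, which gives 53%. They also leave open how a change at this position would combine with the chain change, since the vinyl chain appears here only with bromo on the aromatic carbon.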